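The compounds below may be only part of what the source reports. "The series", "measured", "known", "first", "only" and "open" are said of these compounds alone.

Measured in an ADME assay on L6 cells (Rattus norvegicus) for cytotoxicity, read by resazurin assay, with a stated time of 72 h; a lower number here means a stronger inhibitor, a higher number a weaker inhibitor:
- compound 1 `OC(c1ccc(Cl)cc1)(c1cccnc1)c1ccccc1Cl`: 61300 nM
- compound 2 `OC(c1ccc(Cl)cc1)(c1ccc(Br)cc1)c1cccnc1`: 57000 nM
- compound 3 `COc1ccc(C(O)(c2ccc(Cl)cc2)c2cccnc2)cc1`: 68100 nM

These three compounds cannot be told apart in this assay. Compound 2, at 57000 nM, stands level with the other two within the scatter, so its value serves as a fair reference for the series.

The unmeasured compound 4 `OC(c1ccc(Cl)cc1)(c1cccnc1)c1ccc(Br)cc1F` differs from compound 2 in one place: fluoro in place of hydrogen on an aromatic carbon. Among the measured compounds shown here, this is fluoro in place of hydrogen on an aromatic carbon, and no measured step makes that same change. For the measured compounds named here, two measured steps bear on it indirectly. Exchanging 2-chlorophenyl for 4-bromophenyl gives a 1.1-fold lower number from compound 1 to compound 2 (0.03 log units; within the scatter), and methoxy in place of bromo gives a 1.2-fold higher number from compound 2 to compound 3 (0.08 log units; within the scatter). Both of these steps replace a group on an aromatic part of the molecule, and both stay within the scatter. Three compounds are thin evidence, but they offer no sign of a sizeable shift, so no step beyond the scatter is expected in this assay. The expected change is a 1.0-fold lower number from compound 2 to compound 4 (0.02 log units; within the scatter), which would leave the new value among the others. For compound 4 the estimated value is 55000 nM, with an expected range from 33000 nM to 85000 nM.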

Compound 4, half-maximal inhibitory concentration: 79200 nM
The estimate for compound 4 lay 1.4-fold (0.16 log units) below the measured number; the range from low to high includes it.
By their numbers in this assay, from the lowest: compounds 2, 1, 3 and 4 (each within the scatter of the next).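

In this assay, fluoro in place of hydrogen on an aromatic carbon gives a 1.4-fold higher number from compound 2 to compound 4 (0.14 log units; within the scatter). The earlier steps shown here only exchanged one group for another, whereas this one adds a group to a carbon that carried hydrogen, on the six-membered aromatic ring of carbon only that also holds the bromo group, ortho to a large group and meta to that bromo group. It shows that, for fluoro at least, this open position can be filled without the number leaving the scatter, so all four compounds remain indistinguishable in this assay, and nothing available speaks to what lies behind this result.

The compounds shown leave open whether anything larger on that same carbon, such as an amine or a carboxylic acid, would also stay within the scatter or would be the first change to move the number beyond it. They also leave open whether fluoro at this position would give a similar step with methoxy in place of the bromo group, as in compound 3.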